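The source may hold more compounds than are shown below. What is called first, only, known or untested is meant among the compounds shown, and "the series" means these compounds.

Measured so far in an assay on isolated protein for inhibition of 2-Hydroxyacid oxidase 2 (Homo sapiens), tested at 10 uM; on this read-out higher numbers stand for a stronger effect at the one concentration tested and lower numbers for a weaker effect: compound 1 `Cc1n[nH]c(C(=O)O)c1Cc1cccc(-c2cccc(F)c2)c1` gives 50%; compound 2 `Cc1n[nH]c(C(=O)O)c1Cc1cccc(C(N)=O)c1` gives 8%.

Compound 2 stands lowest of the two numbers; its nearest neighbour is compound 1, and the step between them, a number 42 percentage points lower from compound 1 to compound 2 (beyond the scatter), lies beyond the scatter. Compound 3 `Cc1n[nH]c(C(=O)O)c1Cc1cccc(C(F)(F)F)c1` differs from compound 2 by trifluoromethyl in place of carbamoyl on an aromatic carbon. Among the compounds with values here, the only measured step that bears on this change is a number 42 percentage points lower from compound 1 to compound 2 (beyond the scatter), in which carbamoyl entered for a 3-fluorophenyl group and the read-out fell sharply. Trifluoromethyl, like that 3-fluorophenyl, carries no hydrogen-bond donor and no acceptor, but no measured pair tests trifluoromethyl itself, so the size of the step is uncertain. Compound 3 is therefore expected to recover part of that loss, a step of a number 17 percentage points higher from compound 2 to compound 3 (beyond the scatter). The estimate for compound 3 in this assay is 25%, within a range of 5% to 50%.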

Compound 3, a percentage reported as inhibition, at one concentration (the size of the read-out at that concentration, not a potency): 23%
Estimate against measurement, compound 3: 2 percentage points above; measured number inside the range.
By their numbers in this assay, from the lowest: compound 2; then compound 3; then compound 1.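

In this assay, trifluoromethyl in place of carbamoyl on this aromatic carbon gives a number 15 percentage points higher from compound 2 to compound 3 (beyond the scatter), so the group without a hydrogen-bond donor or acceptor reads above the one that carries both. That gain stops well short of the 3-fluorophenyl level, with a number 27 percentage points lower from compound 1 to compound 3 (beyond the scatter), which shows that lacking a donor and an acceptor does not alone bring back the number of compound 1. Nothing measured here accounts for this order among the three groups.

The compounds shown leave open whether the advantage of 3-fluorophenyl over trifluoromethyl lies in the ring or in its fluorine, which an unsubstituted phenyl would separate. They also leave open whether a group with only an acceptor, such as a methoxy, or only a donor, such as an amine, would read nearer to compound 2 or compound 3.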